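A few compounds are considered here, and "the series" means these few. Any claim that something is new, unique, unknown or untested is made for them only; others in the source may bear on it.

Of the compounds shown here, three built on one shared core have been tested in a functional assay on HCT-116 cells (Homo sapiens) for inhibition, read by MTT assay, with a stated time of 72 h; a lower number here means a stronger inhibitor, a higher number a weaker inhibitor. Compound 1 `Cc1cccc(NC(=O)c2ccc(/N=N\c3c[nH]c4ccccc34)cc2)c1C` gives 272000 nM, compound 2 `O=C(Nc1ccccc1[N+](=O)[O-])c1ccc(/N=N\c2c[nH]c3ccccc23)cc1` gives 208000 nM, and compound 3 `O=C(Nc1ccccc1Cl)c1ccc(/N=N\c2c[nH]c3ccccc23)cc1` gives 120000 nM. Compound 3 carries the lowest number of the three, yet its gap to compound 2, a 1.7-fold lower number from compound 2 to compound 3 (0.24 log units; within the scatter), is within the scatter, and only its gap to compound 1, a 2.3-fold lower number from compound 1 to compound 3 (0.36 log units; beyond the scatter), is beyond it, so compound 3 is separated clearly from compound 1 alone.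

Compound 4 `Cc1ccc(NC(=O)c2ccc(/N=N\c3c[nH]c4ccccc34)cc2)c(C)c1` has not yet been measured. It differs from compound 3 in a single place: 2,4-dimethylphenyl in place of 2-chlorophenyl on an amide-type nitrogen. Among the compounds with values here, the step that bears most on this change is the one between compound 1 and compound 3, because a 2.3-fold lower number from compound 1 to compound 3 (0.36 log units; beyond the scatter) shows that exchanging a 2,3-dimethylphenyl for the 2-chlorophenyl lowered the number modestly; compound 4 returns to a dimethylphenyl, here the 2,4-dimethylphenyl, so the reverse of that step seems likely. The step of a 1.3-fold lower number from compound 1 to compound 2 (0.12 log units; within the scatter) adds little, since it lies within the scatter. A modest rise in this assay is therefore expected. Compound 4 is expected to give 220000 nM, with a range from 100000 nM to 450000 nM. That estimate corresponds to an expected step of a 1.8-fold higher number from compound 3 to compound 4 (0.26 log units; within the scatter).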

Compound 4, half-maximal inhibitory concentration: 76100 nM
Compound 4: middle estimate off by 2.9-fold (0.46 log units), on the high side, outside the stated range (below it).
By their numbers in this assay, from the lowest: compounds 4, 3, 2 and 1 (each within the scatter of the next, the first and the last beyond it).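

In this assay, the change on the amide-type nitrogen from 2-chlorophenyl to 2,4-dimethylphenyl gives a 1.6-fold lower number from compound 3 to compound 4 (0.20 log units; within the scatter) and so does not separate the two compounds, which means a dimethylphenyl group here does not by itself bring back the higher number of compound 1. The new comparison between the two dimethylphenyl groups, which have the same atoms and differ only in how their methyl groups are arranged, gives a 3.6-fold lower number from compound 1 to compound 4 (0.55 log units; beyond the scatter) and lies beyond the scatter, as does the change from 2-nitrophenyl, with a 2.7-fold lower number from compound 2 to compound 4 (0.44 log units; beyond the scatter) in the same assay, so the arrangement of the methyl groups counts at this position among these compounds. No measurement shown here explains why these two dimethylphenyl groups differ.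

The compounds shown leave open whether a single methyl group, or a longer chain such as ethyl or propyl, would follow the 2,4-dimethylphenyl or the 2,3-dimethylphenyl result. Within the data shown here, they also leave open how an amine or a carboxylic acid on the phenyl group would behave, since every group at this position so far carries only methyl, chloro or nitro.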